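This account rests on a few compounds, and the source may have more. Where it says the series, first, only, none or still open, it means among the compounds named here.

Measured compounds:
- compound 1, `COC(=O)C(Nc1cc(CS(=O)(=O)/C=C/c2c(OC)cc(OC)cc2OC)ccc1OC)c1ccccc1`, 75 nM
- compound 2, `COC(=O)C(Nc1cc(CS(=O)(=O)/C=C/c2c(OC)cc(OC)cc2OC)ccc1OC)c1ccc(OC)cc1`, 250 nM

In a functional assay on DU-145 cells (Homo sapiens) for cytotoxicity, read by trypan blue exclusion, with a stated time of 96 h (a higher number here means a weaker inhibitor, a lower number a stronger inhibitor), compound 1 gives the lowest of the two numbers shown. Going by the values given here, compound 2 is the only other compound, and the step of a 3.3-fold higher number from compound 1 to compound 2 (0.52 log units; beyond the scatter) sets compound 1 apart from it. Compound 3, `COc1cc(OC)c(/C=C/S(=O)(=O)Cc2ccc(OC)c(NC(C(=O)O)c3ccc(Br)cc3)c2)c(OC)c1`, is not yet measured. It differs from compound 1 in one place: (4-bromophenyl)(carboxy)methyl in place of methoxycarbonyl)(benzyl on a nitrogen on an aromatic ring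

Among the compounds with values here, no measured step matches this change directly. Within the data shown here, the only step at hand, a 3.3-fold higher number from compound 1 to compound 2 (0.52 log units; beyond the scatter), places a methoxy on an aromatic carbon of the ring that is carried on the nitrogen; in compound 3 that ring is again changed, now carrying a bromine, while the methoxycarbonyl is also exchanged for a carboxy. Among the measured compounds shown here, the single step available points toward a higher number when the ring on the nitrogen gains a substituent, and the exchange of the ester for the acid adds a further, unsampled change. A modestly higher number than compound 1 is therefore expected, with wide uncertainty. The estimated step is a 4.0-fold higher number from compound 1 to compound 3 (0.60 log units; beyond the scatter). Compound 3 is estimated at 300 nM, in a range from 70 nM to 1500 nM.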

Compound 3, half-maximal inhibitory concentration: 300 nM
For compound 3 middle estimate and measured number coincide at the digits printed; low and high end bracket the measured number.
By their numbers in this assay, from the lowest: compound 1; then compounds 2 and 3 (each within the scatter of the next).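

In this assay a second kind of change on a nitrogen on an aromatic ring, (4-bromophenyl)(carboxy)methyl in place of methoxycarbonyl)(benzyl, gives a 4.0-fold higher number from compound 1 to compound 3 (0.60 log units; beyond the scatter) and so shows that this place can take a carboxy and a bromine together while the cytotoxicity stays measurable, with a step that is only modest. Compound 1 now stands lowest of three, so both changes seen at this place raise the number and none of the compounds shown goes against that, although two changes are a thin basis for any pattern. Nothing measured here explains why the number rises. The bromine and the carboxy arrive in a single step, so how much of the rise belongs to each cannot be read from these compounds. Also open, on these data alone, is how the number would respond to a primary amide in place of the carboxy, or to a fluorine or a nitrile in place of the bromine, which would show whether this place responds to the particular group or to almost any change.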